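The source may report more compounds than this note shows. Statements on the series, on what has been measured and on what is new or still open speak of the compounds shown alone.

In a functional assay on DU-145 cells (Homo sapiens) for cytotoxicity, read by trypan blue exclusion, with a stated time of 96 h (a lower number here means a stronger inhibitor, a higher number a weaker inhibitor), compound 1 (`COc1ccc(CS(=O)(=O)/C=C/c2c(OC)cc(OCCCC(=O)O)cc2OC)cc1N`) gives 25000 nM and compound 2 (`COC(=O)C(Nc1cc(CS(=O)(=O)/C=C/c2c(OC)cc(OC)cc2OC)ccc1OC)c1ccccc1`) gives 75 nM as the lower of the two numbers, well beyond the scatter. Compound 3 (`COc1cc(OC)c(/C=C/S(=O)(=O)Cc2ccc(OC)c(NC(C(=O)O)c3ccccc3)c2)c(OC)c1`) remains unmeasured. It departs from compound 2 by hydrogen in place of methyl on an oxygen next to a carbonyl group with hydrogen in place of methyl on an oxygen next to a carbonyl group, methoxycarbonyl to carboxy. Compound 1 also carries a carboxy group and reads 25000 nM but differs elsewhere too, so a moderate rise beyond the scatter is expected. The expected change is a 5.3-fold higher number from compound 2 to compound 3 (0.73 log units; beyond the scatter) in this assay terms. The estimated value for compound 3 is 400 nM (range 80 nM to 4000 nM).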

Compound 3, half-maximal inhibitory concentration: 20 nM
Estimate against measurement, compound 3: 20-fold (1.30 log units) above; measured number below the stated range.
By their numbers in this assay, from the lowest: compound 3; then compound 2; then compound 1.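

In this assay, the change from methoxycarbonyl to carboxy gives (a 3.8-fold lower number from compound 2 to compound 3 (0.57 log units; beyond the scatter)), so a free carboxy group is tolerated here and the methyl on that oxygen is not needed for a low number. Compound 1 also carries a carboxy group but differs from compound 3 in more than one place, so its high number says nothing about this position. No measurement given here explains the step.

As far as these compounds go, whether an amide or a hydroxymethyl group would read like the carboxy group remains open. So does whether an ethyl ester would follow compound 2.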